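A few compounds are considered here, and "the series" means these few. Any claim that something is new, unique, unknown or untested is made for them only; others in the source may bear on it.

Compound 1 `O=C(Nc1ccc(S(F)(F)(F)(F)F)cc1)c1ccc(Sc2ccc(O)cc2)cc1` is tested in a functional assay on LNCaP cells (Homo sapiens) for antiproliferative activity, read by fluorescence and propidium iodide staining, with a stated time of 96 h (on this read-out higher numbers stand for weaker inhibition and lower numbers for stronger inhibition), where compound 1 gives 4860 nM, the lowest of the three numbers at hand. Compound 2 `O=C(Nc1ccc(C(F)(F)F)cc1)c1ccc(Sc2ccc(O)cc2)cc1` gives 8300 nM, and compound 3 `O=C(Nc1ccccc1C(F)(F)F)c1ccc(Sc2ccc(O)cc2)cc1` gives 11400 nM. Going by the values given here, the only single-point step among the measured compounds is a 1.7-fold higher number from compound 1 to compound 2 (0.23 log units; within the scatter), and it concerns a different part of the molecule. Compound 4 `O=C(Nc1ccc(S(F)(F)(F)(F)F)cc1)c1ccc(S(=O)(=O)c2ccc(O)cc2)cc1` differs from compound 1 elsewhere: (4-hydroxyphenyl)sulfonyl in place of (4-hydroxyphenyl)sulfanyl on an aromatic carbon. Among the compounds with values here, no measured step touches this change, so the numbers give no basis for expecting a shift beyond the scatter in either direction. Compound 4 is therefore expected to give 6000 nM, between 2000 nM and 20000 nM. The expected step of a 1.2-fold higher number from compound 1 to compound 4 (0.09 log units; within the scatter) is small, with the wide range reflecting how little is known about this change.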

Compound 4, half-maximal inhibitory concentration: 2490 nM
Estimate against measurement, compound 4: 2.4-fold (0.38 log units) above; low and high end bracket the measured number.
By their numbers in this assay, from the lowest: compounds 4, 1, 2 and 3 (each within the scatter of the next, the first and the last beyond it).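

In this assay, going by these compounds alone, the first measured change at this position, (4-hydroxyphenyl)sulfonyl in place of (4-hydroxyphenyl)sulfanyl, gives a 2.0-fold lower number from compound 1 to compound 4 (0.29 log units; within the scatter). The position therefore accepts the sulfonyl link on the core of compound 1 with a shift that stays within the scatter, so the two links cannot be told apart here. Nothing available bears on the reason for this result.

On these data alone, whether a sulfinyl link, an ether oxygen or a methylene link would behave alike at this place remains open. So does whether the same change would give a similar step on compound 2 or compound 3.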